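Two thiophenes on a shared core: swapping the ring attachment

The source may report more compounds than this note shows. Statements on the series, on what has been measured and on what is new or still open speak of the compounds shown alone.

Measured compounds:
compound 1 `c1csc(-c2cc(-c3ccncc3)nc(-c3ccsc3)c2)c1` gives 14500 nM
compound 2 `c1csc(-c2cc(-c3ccncc3)nc(-c3cccs3)c2)c1` gives 5750 nM
compound 3 `c1cncc(-c2cc(-c3ccco3)cc(-c3cccs3)n2)c1` gives 5900 nM

All three were tested in a functional assay on SK-OV-3 cells (Homo sapiens) for cytotoxicity, read by sulforhodamine B assay, with a stated time of 48 h; on this read-out higher numbers stand for weaker inhibition and lower numbers for stronger inhibition. Compound 1 stands at the highest number of the three, with compound 3 and compound 2 both clearly lower. Compound 4 `c1cc(-c2cc(-c3ccsc3)cc(-c3ccsc3)n2)ccn1` has not yet been measured; it differs from compound 1 in one place: thiophen-3-yl in place of thiophen-2-yl on an aromatic carbon.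

For the measured compounds named here, only one measured step bears on this change, and it runs the other way: a 2.5-fold lower number from compound 1 to compound 2 (0.40 log units; beyond the scatter). There, thiophen-2-yl entering in place of thiophen-3-yl lowered the number by a modest but real amount. In compound 4 the reverse swap is made on a different carbon of the core, so the two thiophenes become alike in the way they attach. Taking the measured step as a rough guide, a modest upward movement in the number is expected, though it could also fall within the scatter. Compound 4 is therefore estimated to give 22000 nM, between 9000 nM and 55000 nM, which means an expected step of a 1.5-fold higher number from compound 1 to compound 4 (0.18 log units; within the scatter).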

Compound 4, half-maximal inhibitory concentration: 9860 nM
Compound 4: the middle estimate sits 2.2-fold (0.35 log units) above what was measured; low and high end bracket the measured number.
By their numbers in this assay, from the lowest: compounds 2, 3, 4 and 1 (each within the scatter of the next, the first and the last beyond it).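

In this assay, putting thiophen-3-yl in place of thiophen-2-yl on the aromatic carbon opposite the ring nitrogen gives a 1.5-fold lower number from compound 1 to compound 4 (0.17 log units; within the scatter), so the numbers for these two compounds cannot be told apart. For the compounds shown here, the only earlier step with a thiophene swap, made on a different carbon of the core, was a 2.5-fold lower number from compound 1 to compound 2 (0.40 log units; beyond the scatter), which lies beyond the scatter, so the same kind of swap does not read out alike at the two carbons, at least in these compounds. No measurement shown here offers an explanation for this contrast.

Thiophen-2-yl and thiophen-3-yl are made of the same atoms and differ only in how they are joined, so it remains open whether the carbon opposite the ring nitrogen would also show so little response to a truly different group, such as an amine, a carboxylic acid or a longer chain. As far as these compounds go, it also remains open whether the same swap would read out the same way with some other group in place of the pyridin-4-yl group.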